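A Benzyl Carbamate Beside a Butyl Carbamate

The compounds below may be only part of what the source reports. "The series", "measured", "known", "first", "only" and "open" are said of these compounds alone.

Of the compounds shown here, two carrying selenium have been tested in a functional assay on HTB-54 cells (Homo sapiens) for cytotoxicity, read by MTT assay, with a stated time of 72 h; a lower number here means a stronger inhibitor of growth, a higher number a weaker inhibitor of growth. Compound 1 `CCCCOC(=O)Nc1ccc([Se]C#N)cc1` gives 17200 nM. Compound 2 `O=C(Nc1ccc([Se][Se]c2ccc(NC(=O)Oc3ccc(F)cc3)cc2)cc1)Oc1ccc(F)cc1` gives 26700 nM, and the two numbers lie within the usual scatter of each other, so neither can be called the stronger.

Compound 3 `N#C[Se]c1ccc(NC(=O)OCc2ccccc2)cc1` is the next case. It differs from compound 1 in one place: phenyl in place of propyl on a saturated chain carbon bound to an oxygen next to a carbonyl group. The carbamate and the selenocyanate of compound 1 are kept.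

Among the measured compounds shown here, no measured pair shows what this exchange does, so the expectation rests on compound 1 alone. The step from compound 1 to compound 3 is expected to be small, a 1.4-fold lower number from compound 1 to compound 3 (0.16 log units; within the scatter), and not beyond the scatter in either direction. Compound 3 is therefore estimated at 12000 nM in this assay, with a range from 4000 nM to 35000 nM.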

Compound 3, concentration for 50% growth inhibition: 27600 nM
Estimate against measurement, compound 3: 2.3-fold (0.36 log units) below, and the stated range covers the measured number.
By their numbers in this assay, from the lowest: compounds 1, 2 and 3 (each within the scatter of the next).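

In this assay, among the compounds shown here, this is the first measured pair at this position: phenyl in place of propyl on a saturated chain carbon bound to an oxygen next to a carbonyl group gives a 1.6-fold higher number from compound 1 to compound 3 (0.21 log units; within the scatter) and so the two numbers cannot be told apart. With the carbamate and the selenocyanate kept, the position holds either a three-carbon chain or a six-membered aromatic ring of carbon only, and the assay separates neither from the other. Nothing measured here explains this result or ties it to a property of either group.

Going by these compounds, whether a longer chain, a cyclohexyl ring or an amine at this place would give a number beyond the scatter remains open. So does whether phenyl and propyl would also match in a compound with a thiocyanate in place of the selenocyanate.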